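Swapping an aryl substituent on a triazole-linked sulfonamide

The source may report more compounds than this note shows. Statements on the series, on what has been measured and on what is new or still open speak of the compounds shown alone.

Measured compounds:
- Compound 1, `Cc1ccc(-n2cc(-c3ccccc3NS(=O)(=O)c3c[nH]c(=O)[nH]c3=O)nn2)cc1`: 8350 nM
- Compound 2, `O=c1[nH]cc(S(=O)(=O)Nc2ccccc2-c2cn(-c3ccc(Cl)cc3)nn2)c(=O)[nH]1`: 1840 nM
- Compound 3, `Cc1cccc(-n2cc(-c3cccc(NS(=O)(=O)c4c[nH]c(=O)[nH]c4=O)c3)nn2)c1`: 7050 nM

All three share the same core and were tested in a functional assay on HepG2 cells (Homo sapiens) for antiproliferative activity, read by MTT assay, with a stated time of 24 h; a lower number here means a stronger inhibitor, a higher number a weaker inhibitor. Compound 3 gives 7050 nM, the second highest of the three numbers. Its nearest neighbour is compound 1, whose value sits within the scatter of that of compound 3, so the two cannot be told apart. Compound 2 lies further away, with a number beyond the scatter below that of compound 3.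

The next compound, compound 4 `O=c1[nH]cc(S(=O)(=O)Nc2cccc(-c3cn(-c4ccc(Cl)cc4)nn3)c2)c(=O)[nH]1`, is not yet measured. It differs from compound 3 in one place: 4-chlorophenyl in place of 3-methylphenyl on an aromatic nitrogen.

For the measured compounds named here, one measured step bears on this change. Going a 4.5-fold lower number from compound 1 to compound 2 (0.66 log units; beyond the scatter), the same exchange of a methyl for a chlorine on the aryl ring gave a modest drop in the number. Going by the values given here, the change from compound 3 to compound 4 also moves the substituent to a different spot on that ring, for which no measured step exists, so the comparison is only partial. Among the compounds with values here, still, the one step available points to a lower number, and a step of similar size is expected, a 3.7-fold lower number from compound 3 to compound 4 (0.57 log units; beyond the scatter).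

Compound 4 is therefore estimated at 1900 nM, with a plausible range from 800 nM to 5000 nM.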

Compound 4, half-maximal inhibitory concentration: 1960 nM
For compound 4 the middle estimate is 1.0-fold (0.01 log units) below the measured one; low and high end bracket the measured number.
By their numbers in this assay, from the lowest: compounds 2 and 4 (each within the scatter of the next); then compounds 3 and 1 (each within the scatter of the next).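

In this assay, the exchange on the aromatic nitrogen gives a 3.6-fold lower number from compound 3 to compound 4 (0.56 log units; beyond the scatter), so the aryl group at this position matters in a second pair of compounds as well as in the first. The earlier step, a 4.5-fold lower number from compound 1 to compound 2 (0.66 log units; beyond the scatter), changed only methyl to chlorine in one pair, and it could not show whether the same direction would hold where the groups on the shared core are arranged differently, as they are in compound 3 and compound 4. Both steps lie beyond the scatter and point the same way, with no pair shown going against them, but no measurement here accounts for this shift.

The step from compound 3 to compound 4 changes both the substituent and its place on the aryl ring, so the part played by each remains unresolved, and a 3-chlorophenyl or 4-methylphenyl group on the same nitrogen would be needed to separate them. From the compounds shown here alone, how an aryl ring carrying an amine or a carboxylic acid would behave in this assay also remains open.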